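Moving the Methyl Around a Morpholine Ring

This account rests on a few compounds, and the source may have more. Where it says the series, first, only, none or still open, it means among the compounds named here.

Measured compounds:
compound 1 `Cc1cc(Cl)cc(-c2ccnc3cc(CN4C(=O)C5CC5C4=O)sc23)c1C[C@@H]1CNC[C@@H](C)O1` — in an assay on isolated protein for inhibition of ubiquitin carboxyl-terminal hydrolase 7 (Homo sapiens), read by fluorescence, with stated times of 30 min and 1 h (a lower number here means a stronger inhibitor, a higher number a weaker inhibitor), compound 1 gives 0.39 nM
compound 2 `O=C([C@H]1Cc2cc(Cl)cc(-c3ccnc4cc(C5(O)COC5)sc34)c2O1)N1CCNCC1` — in this assay compound 2 gives 73 nM

Of the compounds shown here, two have been measured, and compound 1 has the lower of the two numbers, meaning it is the stronger inhibitor. Compound 2 sits far above it, by a gap well beyond the usual scatter of repeated measurements. The two differ in several places at once, so nothing can be said about which of those differences matters.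

Compound 3 `Cc1cc(Cl)cc(-c2ccnc3cc(CN4C(=O)C5CC5C4=O)sc23)c1C[C@H]1OCCN[C@@H]1C` is not yet measured. It keeps everything in compound 1 except one detail: 3-methylmorpholin-2-yl in place of 6-methylmorpholin-2-yl on a saturated chain carbon bound to an aromatic carbon. The same atoms are present, but the methyl sits on a different carbon of the six-membered ring, and the two defined stereocentres are arranged accordingly. Nothing measured here tells how that ring responds to such a rearrangement.

Going by the values given here, with no comparable step to lean on, a modest weakening is the expectation, though a result within the scatter would not surprise. The step from compound 1 to compound 3 is estimated at a 3.8-fold higher number from compound 1 to compound 3 (0.59 log units; beyond the scatter). Compound 3 is expected to give 1.5 nM, within 0.3 nM to 10 nM.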

Compound 3, half-maximal inhibitory concentration: 1.5 nM
For compound 3 middle estimate and measured number coincide at the digits printed; low and high end bracket the measured number.
By their numbers in this assay, from the lowest: compound 1; then compound 3; then compound 2.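

Moving the methyl so that 3-methylmorpholin-2-yl replaces 6-methylmorpholin-2-yl leaves the atoms and the counted hydrogen-bond donors and acceptors unchanged, yet it gives a 3.8-fold higher number from compound 1 to compound 3 (0.59 log units; beyond the scatter) in this assay. Going by these compounds alone, this is the first sign that inhibition depends on the arrangement of this ring and not only on its composition, although the step is modest and compound 3 remains a potent inhibitor at 1.5 nM in the low nanomolar range. No supporting measurement explains the size of this step, and this single pair cannot separate the new place of the methyl from the new arrangement of the two defined stereocentres.

The compounds shown leave open how the other stereoisomers of the 3-methylmorpholin-2-yl and 6-methylmorpholin-2-yl groups would compare, since each appears here in only one form. As far as these compounds go, they also leave open what would happen with a plain morpholin-2-yl group carrying no methyl, or with an ethyl group in the methyl's place, so the contribution of the methyl itself remains unknown.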